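The source may report more compounds than this note shows. Statements on the series, on what has been measured and on what is new or still open speak of the compounds shown alone.

Compound 1 `CCC(=O)O[C@@H]1CO[C@H]2[C@@H]1OC[C@@H]2OC(=O)c1ccccc1OC(C)=O` stands lowest of the three measured compounds in an ADME assay on a cell-free system (plasma, Homo sapiens) for metabolic stability, with Plasma (Rattus norvegicus) as the target, read by HPLC, at pH 7.4 (on this read-out lower numbers stand for a shorter-lived compound and higher numbers for a longer-lived compound), where compound 1 gives 0.011 h. Compound 2 `CC(=O)Oc1ccccc1C(=O)O[C@H]1CO[C@H]2[C@@H]1OC[C@H]2OC(=O)c1ccc(C)cc1` gives 0.0362 h, and compound 3 `CCOc1cc(OCC)cc(C(=O)O[C@@H]2CO[C@H]3[C@@H]2OC[C@@H]3OC(=O)c2ccccc2OC(C)=O)c1` gives 0.0283 h. Compound 4 `CC(=O)Oc1ccccc1C(=O)O[C@H]1CO[C@H]2[C@@H]1OC[C@H]2OC(=O)c1cc(C)nc(Cl)c1` differs from compound 1 in one place: 2-chloro-6-methylpyridin-4-yl in place of ethyl on a carbonyl carbon. Two measured steps replace the same ethyl on that carbonyl carbon with an aromatic ring, giving a 3.3-fold higher number from compound 1 to compound 2 (0.52 log units; beyond the scatter) and a 2.6-fold higher number from compound 1 to compound 3 (0.41 log units; beyond the scatter), both beyond the scatter and in the same direction. Between the two aromatic rings the difference is a 1.3-fold lower number from compound 2 to compound 3 (0.11 log units; within the scatter), so the identity of the ring mattered little there. A comparable modest rise is therefore expected for compound 4, a 3.0-fold higher number from compound 1 to compound 4 (0.48 log units; beyond the scatter). In this assay compound 4 is estimated at 0.033 h, in the range 0.015 h to 0.07 h.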

Compound 4, half-life: 0.0193 h
Compound 4: middle estimate off by 1.7-fold (0.23 log units), on the high side; measured number inside the range.
By their numbers in this assay, from the lowest: compounds 1, 4, 3 and 2 (each within the scatter of the next, the first and the last beyond it).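

On this carbonyl carbon, an aromatic ring does not always clear the scatter against ethyl: 2-chloro-6-methylpyridin-4-yl gives a 1.8-fold higher number from compound 1 to compound 4 (0.24 log units; within the scatter), whereas the two earlier rings stood beyond it. This ring also stays within the scatter of the other two, with a 1.5-fold lower number from compound 3 to compound 4 (0.17 log units; within the scatter) and a 1.9-fold lower number from compound 2 to compound 4 (0.27 log units; within the scatter), so the three rings cannot be told apart here. No supporting data bear on this result. As far as these compounds go, whether a longer alkyl chain, or an aromatic ring carrying an amine or a carboxylic acid, would shift the half-life beyond the scatter remains open.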